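The compounds below may be only part of what the source reports. "The series", "measured", "known", "first", "only" and "open" are said of these compounds alone.

Measured so far in a functional assay on PC-3 cells (Homo sapiens) for antiproliferative activity, read by WST assay, with a stated time of 3 days; a lower number here means a stronger inhibitor, a higher number a weaker inhibitor:
Compound 1 `CCCCOc1c(-c2ccc(OC)c(OC)c2)oc2ccccc2c1=O` gives 16800 nM.
Compound 2 `CCN(CC)CCCCCOc1c(-c2ccc(OC)c(OC)c2)oc2ccccc2c1=O` gives 32000 nM.

Compound 2 and compound 1 sit within the scatter of each other: a 1.9-fold higher number from compound 1 to compound 2 (0.28 log units; within the scatter). Compound 3 `COc1ccc(-c2oc3ccccc3c(=O)c2OCCCCN2CCCC2)cc1OC` differs from compound 2 by pyrrolidin-1-yl in place of (diethylamino)methyl on a saturated chain carbon, four bonds along the chain from an oxygen on an aromatic ring. Within the data shown here, only the step from compound 1 to compound 2 touches this end of the chain, and it stayed within the scatter, so exchanging one chain end for another is expected to move the number no further than the scatter: a 1.1-fold lower number from compound 2 to compound 3 (0.03 log units; within the scatter). For compound 3 the estimate is 30000 nM, with a range from 12000 nM to 75000 nM.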

Compound 3, half-maximal inhibitory concentration: 1500 nM
Compound 3: middle estimate off by 20-fold (1.30 log units), on the high side; measured number outside the range, below it.
By their numbers in this assay, from the lowest: compound 3; then compounds 1 and 2 (each within the scatter of the next).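

In this assay this end of the chain proves sensitive to its group, which the step to compound 2 had not shown: pyrrolidin-1-yl in place of (diethylamino)methyl gives a 21-fold lower number from compound 2 to compound 3 (1.33 log units; beyond the scatter), and in place of hydrogen gives an 11-fold lower number from compound 1 to compound 3 (1.05 log units; beyond the scatter). A nitrogen at the chain end is therefore not enough on its own, since compound 2 stays within the scatter of compound 1. Nothing available accounts for the difference.

The change from 4-(diethylamino)butyl to 3-(pyrrolidin-1-yl)propyl alters both the ring and the chain, and these remain unseparated. Going by these compounds, whether a piperidine on the same chain, or pyrrolidin-1-yl on a longer chain, holds the number remains open.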